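The source may report more compounds than this note shows. Statements on the series, on what has been measured and on what is new or still open speak of the compounds shown alone.

Compounds measured in a functional assay on CCRF-CEM cells (Homo sapiens) for cytotoxicity, in the absence of a further agent; a lower number here means a stronger inhibitor, a higher number a weaker inhibitor:
- Compound 1 `COC(=O)c1ccc(CN(CCCc2c(N)nc(N)nc2O)c2cc(F)cc(F)c2[N+](=O)[O-])cc1`: > 100000 nM (a limit)
- Compound 2 `Nc1nc(N)c(CCCN(Cc2ccc(NC(CCC(=O)O)C(=O)O)cc2)c2cc(F)c([N+](=O)[O-])cc2[N+](=O)[O-])c(O)n1`: 40000 nM
- Compound 3 `Nc1nc(N)c(CCCNc2cc(F)ccc2[N+](=O)[O-])c(O)n1`: > 100000 nM (a limit)

Compound 3 gives no number, only a limit of the assay, and it stands at the limit of > 100000 nM in this assay, at which 2 of the 3 values shown sit. Of the three compounds, only compound 2 returns an actual number.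

The next compound, compound 4 `Nc1nc(N)c(CCCNc2cc(F)cc(F)c2[N+](=O)[O-])c(O)n1`, has a fluoro group in place of a hydrogen on an aromatic carbon of compound 3, ortho to a nitro group and meta to the fluoro group already there: fluoro in place of hydrogen on an aromatic carbon. Compound 1, which also carries two fluoro groups on its nitro-bearing ring, reads > 100000 nM, again a limit. With that in view, no change beyond the scatter is expected in this assay, and compound 4 will most likely report only a limit as well. The expected step is a number no higher from compound 3 to compound 4 (the limit leaves the size open). For compound 4 the estimated value is 100000 nM, with an expected range from 40000 nM to 200000 nM.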

Compound 4, half-maximal inhibitory concentration: 97000 nM
Beside the measured number, compound 4's estimate is 1.0-fold (0.01 log units) above it; the measured number falls inside the stated range.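

In this assay, fluoro in place of hydrogen on an aromatic carbon, ortho to a nitro group and meta to a fluoro group, gives an at least 1.0-fold lower number from compound 3 to compound 4 (0.01 log units; that floor lies within the scatter), so this change shows no shift beyond the scatter at this position. Hydrogen in place of 4-(methoxycarbonyl)benzyl on a nitrogen on an aromatic ring gives an at least 1.0-fold lower number from compound 1 to compound 4 (0.01 log units; that floor lies within the scatter), and this floor likewise shows no shift beyond the scatter. What is new is only that compound 4 returns an actual number, and that number still lies close to where the readings of this assay stop: the limit of > 100000 nM in this assay, at which 2 of the 4 values shown sit.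

The compounds shown leave open whether chloro, a methoxy group or an amine in this place would move the number beyond the scatter. They also leave open whether a carboxylic acid in place of the methyl ester of the 4-(methoxycarbonyl)benzyl group would bring compound 1 off its limit.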